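Cyclopropyl for methyl on the imidazole carbon of compound 1

This account rests on a few compounds, and the source may have more. Where it says the series, first, only, none or still open, it means among the compounds named here.

Measured compounds:
- compound 1 `Cc1c(C(=O)NCc2ccccc2)nc(-c2ccc(F)cc2)n1CC[C@@H](O)C[C@@H](O)CC(=O)O`: 94 nM
- compound 2 `COc1ccccc1CNC(=O)c1nc(-c2ccc(F)cc2)n(CC[C@@H](O)C[C@@H](O)CC(=O)O)c1C1CC1`: 7 nM
- compound 3 `CC(C)c1c(C(=O)NCc2ccccc2)nc(-c2ccc(F)cc2)n1CC[C@@H](O)C[C@@H](O)CC(=O)O`: 7.9 nM

In an assay on microsomes from liver for inhibition of 3-hydroxy-3-methylglutaryl-coenzyme A reductase (Rattus norvegicus), read by scintillation counting, with stated times of 0.5 h and 0.75 h (a lower number here means a stronger inhibitor, a higher number a weaker inhibitor), compound 1 gives the highest number of the three, so it is the weakest inhibitor shown. Its nearest neighbour is compound 3, reached by a 12-fold lower number from compound 1 to compound 3 (1.08 log units; beyond the scatter), a large step beyond the scatter. Within the data shown here, compound 2 lies even further away, at 7 nM, though it also carries a methoxybenzyl amide instead of the benzyl amide, so no single step connects it to compound 1.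

Compound 4 `O=C(O)C[C@H](O)C[C@H](O)CCn1c(-c2ccc(F)cc2)nc(C(=O)NCc2ccccc2)c1C1CC1` is not yet measured. Its difference from compound 1 is cyclopropyl in place of methyl on an aromatic carbon. Among the measured compounds shown here, the one measured step that bears on this change is a 12-fold lower number from compound 1 to compound 3 (1.08 log units; beyond the scatter), where a larger group at the same aromatic carbon cut the number sharply. Compound 2, which already carries cyclopropyl at that carbon, also sits low. A step of similar size and direction is therefore expected, a 10-fold lower number from compound 1 to compound 4 (1.02 log units; beyond the scatter). Compound 4 is estimated at 9 nM, within a range of 4 nM to 22 nM.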

Compound 4, half-maximal inhibitory concentration: 1.4 nM
Compound 4: middle estimate off by 6.4-fold (0.81 log units), on the high side; the whole stated range lies above it.
By their numbers in this assay, from the lowest: compound 4; then compounds 2 and 3 (each within the scatter of the next); then compound 1.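

Cyclopropyl does more at this carbon than simply replace methyl with something larger: swapping it for methyl gives a 67-fold lower number from compound 1 to compound 4 (1.83 log units; beyond the scatter), and it also improves on isopropyl, with a 5.6-fold lower number from compound 3 to compound 4 (0.75 log units; beyond the scatter). With cyclopropyl in place, the methoxy group on the benzyl amide is not needed for a low number, since replacing it with hydrogen gives a 5.0-fold lower number from compound 2 to compound 4 (0.70 log units; beyond the scatter). No measurement here explains why cyclopropyl outperforms isopropyl at this carbon.

Going by these compounds, it remains open whether a cyclobutyl or tert-butyl group at this carbon would give a number lower still, or a higher one. Also open, on these data alone, is whether a different group on the benzyl ring, such as a chlorine or a hydroxyl, would lower the number alongside cyclopropyl or raise it, as methoxy does.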